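The compounds below may be only part of what the source reports. "The series", "measured", "known", "first", "only" and "open" are said of these compounds alone.

Measured compounds:
- compound 1, `NC(=O)CC[C@H](NC(=O)CN(c1ncnc2c1ncn2C1CCCCO1)C1CC1)C(=O)OCc1ccccc1`, 47%
- compound 2, `CSCC[C@H](NC(=O)CN(c1nc(Cl)nc2[nH]cnc12)C1CC1)C(=O)O`, 20.4%
- compound 3, `C[C@H](NC(=O)CN(c1nc(Cl)nc2[nH]cnc12)C1CC1)C(=O)O`, 48.1%

In a functional assay on the whole organism (Tail, strain ICR) with Mus musculus as the target, in the tail flick test, with a stated time of 30 min, at a dose of 25 umol/kg by the oral route (on this read-out higher numbers stand for a stronger effect at the one dose given and lower numbers for a weaker effect), compound 1 stands second of the three numbers; its value sits within the scatter of compound 3 and well above compound 2. Compound 4, `CC(C)[C@H](NC(=O)CN(c1ncnc2c1ncn2C1CCCCO1)C1CC1)C(=O)OCc1ccccc1`, has not yet been measured. It differs from compound 1 in one place: isopropyl in place of 2-carbamoylethyl on a saturated chain carbon bound to an amide-type nitrogen and a carbonyl carbon. One measured step changes the same saturated chain carbon, though with a different pair of groups and on a core that differs in two other places: a number 27.7 percentage points higher from compound 2 to compound 3 (beyond the scatter). That step shows that swapping the group on this carbon can move the read-out by a modest amount, but it gives no direct guidance for an isopropyl in place of a 2-carbamoylethyl, so no direction can be inferred. The step from compound 1 to compound 4 is therefore expected to be small, a number 2 percentage points lower from compound 1 to compound 4 (within the scatter), with a wide range to cover either direction. Compound 4 is estimated at 45%, between 20% and 70%.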

Compound 4, a percentage reported as activity, at one dose (the size of the read-out at that dose, not a potency): 21.8%
Compound 4: middle estimate off by 23.2 percentage points, on the high side, and the stated range covers the measured number.
By their numbers in this assay, from the lowest: compounds 2 and 4 (each within the scatter of the next); then compounds 1 and 3 (each within the scatter of the next).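

In this assay the group on this saturated chain carbon matters on the core of compound 1 itself, not only on the different core of the earlier step: isopropyl in place of 2-carbamoylethyl gives a number 25.2 percentage points lower from compound 1 to compound 4 (beyond the scatter) on an otherwise unchanged structure. The group that leaves has 5 heavy atoms, with 1 hydrogen-bond donor and 1 hydrogen-bond acceptor, while the group that enters has 3 heavy atoms and neither, so this single pair cannot separate size from the loss of the amide. Nothing available explains the drop.

Going by these compounds, it remains open whether an amine, a carboxylic acid or a simple unbranched butyl chain at this carbon would behave like 2-carbamoylethyl or like isopropyl. On these data alone, it is equally open whether isopropyl would act the same way on the core of compound 3.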